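A few compounds are considered here, and "the series" means these few. Any claim that something is new, unique, unknown or untested is made for them only; others in the source may bear on it.

Three urea compounds built on a shared core have been tested in a functional assay on NCI-H460 cells (Homo sapiens) for antiproliferative activity, read by MTT assay, with a stated time of 72 h; a lower number here means a stronger inhibitor, a higher number a weaker inhibitor. Compound 1, `CN(C)CCn1cnnc1-c1cc(Oc2ccc(NC(=O)Nc3ccc(F)c(Cl)c3)cc2F)ccn1`, gives 1580 nM in this assay. Compound 2, `CN(C)CCn1cnnc1-c1cc(Oc2ccc(NC(=O)Nc3ccc(Cl)cc3Cl)cc2F)ccn1`, gives 4350 nM. Compound 3, `CN(C)CCCn1cnnc1-c1cc(Oc2ccc(NC(=O)Nc3ccc(F)c(Cl)c3)cc2F)ccn1`, gives 1270 nM.

Compound 1 and compound 2 differ in one place: 2,4-dichlorophenyl in place of 3-chloro-4-fluorophenyl on an amide-type nitrogen. That change brought a 2.8-fold higher number from compound 1 to compound 2 (0.44 log units; beyond the scatter), so the dichlorinated ring gave a weaker inhibitor in this pairing.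

Compound 1 and compound 3 differ only in the chain on the triazole nitrogen: (dimethylamino)methyl in place of dimethylamino on a saturated chain carbon, two bonds along the chain from an aromatic nitrogen. Lengthening that chain gave a 1.2-fold lower number from compound 1 to compound 3 (0.09 log units; within the scatter), so the two chain lengths cannot be told apart in this assay.

Compound 4, `CN(C)CCCn1cnnc1-c1cc(Oc2ccc(NC(=O)Nc3ccc(Cl)cc3Cl)cc2F)ccn1`, has not yet been measured. It carries the longer chain of compound 3 together with the ring change already seen between compound 1 and compound 2: 2,4-dichlorophenyl in place of 3-chloro-4-fluorophenyl on an amide-type nitrogen. The place of this change is described in the same words for both pairs, so it is the same change made on a core that differs only by the chain length. Since the chain change from compound 1 to compound 3 left the number within the scatter, the ring change seen from compound 1 to compound 2 is expected to carry over to the longer chain at about the same size. The step expected for compound 4 is therefore a 2.8-fold higher number from compound 3 to compound 4 (0.44 log units; beyond the scatter). On that basis compound 4 is estimated to give 3500 nM in this assay, most likely between 1800 nM and 7000 nM.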

Compound 4, half-maximal inhibitory concentration: 3680 nM
For compound 4 the middle estimate is 1.1-fold (0.02 log units) below the measured one; the range from low to high includes it.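

In this assay, putting 2,4-dichlorophenyl in place of 3-chloro-4-fluorophenyl on the longer-chain core gave a 2.9-fold higher number from compound 3 to compound 4 (0.46 log units; beyond the scatter), and this ring change reads the same on both cores: the same change on two cores in this assay, a 2.8-fold higher number (0.44 log units; beyond the scatter) from compound 1 to compound 2 and a 2.9-fold higher number (0.46 log units; beyond the scatter) from compound 3 to compound 4, 1.1-fold (0.02 log units) apart, within the scatter of two such steps. The chain change, read with the 2,4-dichlorophenyl ring in place, gave a 1.2-fold lower number from compound 2 to compound 4 (0.07 log units; within the scatter), and it also reads the same on both cores: the same change on two cores in this assay, a 1.2-fold lower number (0.09 log units; within the scatter) from compound 1 to compound 3 and a 1.2-fold lower number (0.07 log units; within the scatter) from compound 2 to compound 4, 1.1-fold (0.02 log units) apart, within the scatter of two such steps. Across these four compounds, the size of the ring step therefore held with either chain, and the chain step stayed within the scatter with either ring, but this does not show that the ring step would hold on cores with other chains or in other assays, nor does it explain why the number changes with the ring.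

The compounds shown leave open how other groups on the amide-type nitrogen, such as 4-chlorophenyl or 3-(trifluoromethyl)phenyl, would compare with these two rings. They also leave open what a still longer chain, or a morpholine in place of the dimethylamino group, would do to the number and whether the ring step would keep its size on such cores.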